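Thioamide amine swap on the methoxy-pyrrolidine urea series

A few compounds are considered here, and "the series" means these few. Any claim that something is new, unique, unknown or untested is made for them only; others in the source may bear on it.

Compound 3 `CO[C@@H]1C[C@@H](C(=S)N2CCC(N3CCCC3)CC2)N(C(=O)NCc2ccc(C(=O)N3CCCCc4sccc43)cc2Cl)C1` gives 100 nM in an assay on isolated protein with Vasopressin V2 receptor (Homo sapiens) as the target (on this read-out lower numbers stand for an effect already at smaller amounts and higher numbers for an effect only at larger amounts of compound), and holds the lowest number of the three measured; compound 1 `Cc1cc(C(=O)N2CCCCc3sccc32)ccc1CNC(=O)N1CCC[C@H]1C(=S)N1CCCN(C)CC1` gives 890 nM and compound 2 `CN1CCCN(C(=S)[C@@H]2CCCN2C(=O)NCc2ccc(C(=O)N3CCCCc4sccc43)cc2Cl)CC1` gives 1800 nM in this assay. For the measured compounds named here, the only single-point step measured so far is a 2.0-fold higher number from compound 1 to compound 2 (0.31 log units; beyond the scatter), and it concerns the aromatic substituent, not the thioamide amine. Compound 4 `CO[C@@H]1C[C@@H](C(=S)N2CCCN(C)CC2)N(C(=O)NCc2ccc(C(=O)N3CCCCc4sccc43)cc2Cl)C1` carries the change (4-methyl-1,4-diazepan-1-yl in place of 4-(pyrrolidin-1-yl)piperidin-1-yl on a thiocarbonyl carbon). Going by the values given here, no measured pair isolates this swap: compound 2 and compound 3 differ in the amine and also in the methoxy group on the core, so their values show only that the combination of both changes spans a large gap in this assay. Among the compounds with values here, with no direct precedent, the step is expected to fall between the unchanged value of compound 3 and the value of compound 2, and compound 4 is estimated at 450 nM in this assay, spanning 140 nM to 1600 nM. The expected step is a 4.5-fold higher number from compound 3 to compound 4 (0.65 log units; beyond the scatter).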

Compound 4, half-maximal effective concentration: 230 nM
For compound 4 the middle estimate is 2.0-fold (0.29 log units) above the measured one, within the range that was stated.
By their numbers in this assay, from the lowest: compound 3; then compound 4; then compound 1; then compound 2.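

In this assay, the amine on the thiocarbonyl carbon can now be read on its own: 4-methyl-1,4-diazepan-1-yl in place of 4-(pyrrolidin-1-yl)piperidin-1-yl gives a 2.3-fold higher number from compound 3 to compound 4 (0.36 log units; beyond the scatter) and so costs only a modest step on the methoxy core. Methoxy in place of hydrogen on a saturated ring carbon, with 4-methyl-1,4-diazepan-1-yl held constant, gives a 7.8-fold lower number from compound 2 to compound 4 (0.89 log units; beyond the scatter) and is the larger of the two single-point steps. No measurement on hand explains the size of either step.

On these data alone, each step rests on a single pair, so it remains open whether the methoxy step holds with 4-(pyrrolidin-1-yl)piperidin-1-yl on the thiocarbonyl carbon. Also open, as far as these compounds go, is how a hydroxyl in place of the methoxy, or a morpholin-4-yl as the thioamide amine, would read in this assay.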